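Varying the amide side group of a shared vitamin D receptor core

The compounds below may be only part of what the source reports. "The series", "measured", "known", "first", "only" and "open" are said of these compounds alone.

Measured so far in an assay on cells for agonist activity at vitamin D3 receptor (Homo sapiens), with a stated time of 96 h; a lower number here means that less compound is needed, a higher number that more compound is needed for the effect:
compound 1 `CCn1c(C(=O)NCCN(C)C)ccc1C(CC)(CC)c1ccc(OCCC(O)(CC)CC)c(C)c1` gives 82 nM;
compound 2 `CCN(CC)CCNC(=O)c1ccc(C(CC)(CC)c2ccc(OCCC(O)(CC)CC)c(C)c2)n1CC` gives 2.3 nM;
compound 3 `CCn1c(C(=O)NCCN)ccc1C(CC)(CC)c1ccc(OCCC(O)(CC)CC)c(C)c1` gives 156 nM.

Compound 3 has the highest number of the three; the step of a 1.9-fold higher number from compound 1 to compound 3 (0.28 log units; within the scatter) is within the scatter, whereas the step of a 68-fold higher number from compound 2 to compound 3 (1.83 log units; beyond the scatter) is large. Compound 4 `CCn1c(C(=O)N(CCC#N)CCC#N)ccc1C(CC)(CC)c1ccc(OCCC(O)(CC)CC)c(C)c1` differs from compound 3 by a group of 9 heavy atoms (6 carbon, 3 nitrogen; no ring) in place of a group of 4 heavy atoms (2 carbon, 2 nitrogen; no ring), on a carbonyl carbon. The steps of a 36-fold lower number from compound 1 to compound 2 (1.55 log units; beyond the scatter) and a 68-fold higher number from compound 2 to compound 3 (1.83 log units; beyond the scatter) both lie on the same amide side group, so a large step in this assay is plausible; neither measured step, however, involves a group without a chain amine, so the direction is uncertain. Compound 4 is expected to give 200 nM (range 30 nM to 1500 nM), an estimated step of a 1.3-fold higher number from compound 3 to compound 4 (0.11 log units; within the scatter).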

Compound 4, half-maximal effective concentration: > 10000 nM
Compound 4: only a limit was reported (the forecaster's own chance of this, stated with the estimate: 10%); middle value at least 50-fold (1.69 log units) from the limit.
By their numbers in this assay, from the lowest: compound 2; then compounds 1 and 3 (each within the scatter of the next). At a limit, above all of these: compound 4.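

In this assay compound 4 gives only a limit of the assay, not a number: the limit of > 10000 nM in this assay, at which 1 of the 4 values shown sits.

Thus an at least 64-fold higher number from compound 3 to compound 4 (1.80 log units; beyond the scatter) and an at least 120-fold higher number from compound 1 to compound 4 (2.08 log units; beyond the scatter) and an at least 4300-fold higher number from compound 2 to compound 4 (3.63 log units; beyond the scatter) all count as large on the carbonyl carbon. The earlier compounds shown here all carry a chain amine and the amide hydrogen and all give numbers, whereas compound 4 carries neither, so a change at this place can run past the limit of the assay rather than only shift the number.

Compound 4 changes the amine and the amide hydrogen together, and the compounds shown do not separate the two. From the compounds shown here alone, whether a single chain ending in a nitrile, or a chain amine on a fully substituted amide nitrogen, would stay measurable remains open.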